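A Large Step Expected Back From Compound 2

This account rests on a few compounds, and the source may have more. Where it says the series, first, only, none or still open, it means among the compounds named here.

Compound 1 `CCC/N=C1\S/C(=C\c2ccc(O)c(Cl)c2)C(=O)N1C1CCOCC1` gives 3.7 in a physicochemical assay for lipophilicity, read by HPLC, at pH 7.4 (on this read-out lower numbers stand for lower lipophilicity and higher numbers for higher lipophilicity), here.
Compound 2 `CCC/N=C1\S/C(=C\c2ccc(O)c(Cl)c2)C(=O)N1C1CCN(C)C(=O)C1` gives 0.6 in this assay here.

Of these two numbers, compound 2 holds the lower, at 0.6 in this assay, and compound 1 stands well above it. Compound 3 `CCC/N=C1\S/C(=C\c2ccc(O)c(Cl)c2)C(=O)N1C(C)C` has not yet been measured. The change leading to it is isopropyl in place of 1-methyl-2-oxopiperidin-4-yl on an amide-type nitrogen in a ring and it puts isopropyl in place of 1-methyl-2-oxopiperidin-4-yl on an amide-type nitrogen in a ring.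

Among the measured compounds shown here, one measured step bears on this change, and it was large: a number 3.10 log units lower from compound 1 to compound 2 (beyond the scatter) at the same place. That step brought in the very group that now leaves. Isopropyl itself has no measured value on the shared core, so the size of the return cannot be read off directly. Compound 3 is nonetheless expected to lie near compound 1, with its 3.7 as the reference, and far from compound 2.

The expected step is a number 3.80 log units higher from compound 2 to compound 3 (beyond the scatter) and thus large and upward. For compound 3 the estimated value is 4.4 with an expected range from 3.8 to 5 in this assay when it is measured.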

Compound 3, distribution coefficient: > 4.3
Compound 3 gave a limit, no number; the forecaster's own chance of this, stated with the estimate: 3%; the middle value does not contradict the limit.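

The reading for compound 3 is a limit of this assay and not a number: the limit of > 4.3 in this assay, at which 1 of the 3 values shown sits.

Even so, it shows that at this place, on an amide-type nitrogen in a ring, isopropyl in place of 1-methyl-2-oxopiperidin-4-yl gives a number at least 3.70 log units higher from compound 2 to compound 3 (beyond the scatter), so this change more than takes back the fall that came with bringing in 1-methyl-2-oxopiperidin-4-yl. It also shows that oxan-4-yl did not mark the top of the range at this position, for isopropyl in its place gives a number at least 0.60 log units higher from compound 1 to compound 3 (beyond the scatter). The three groups thus fall into a clear order on this read-out, with isopropyl highest, oxan-4-yl in the middle and 1-methyl-2-oxopiperidin-4-yl lowest, although the top end of that range has no fixed value.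

On these data alone, how far compound 3 actually lies beyond its limit remains open, so both new steps have a lower bound but no upper one. Also open, as far as these compounds go, is where a group such as an amine, a carboxylic acid or a longer alkyl chain would fall in this order at the same place on the shared core.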